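Removing a Nitro Group from Compound 1

This account rests on a few compounds, and the source may have more. Where it says the series, first, only, none or still open, it means among the compounds named here.

Going by the values given here, in a functional assay on CCRF-CEM cells (Homo sapiens) for cytotoxicity, in the absence of a further agent (on this read-out higher numbers stand for weaker inhibition and lower numbers for stronger inhibition), compound 1 `Nc1nc(N)c(CCCN(Cc2ccc(NC(CCC(=O)O)C(=O)O)cc2)c2cc(F)c([N+](=O)[O-])cc2[N+](=O)[O-])c(O)n1` gives 44000 nM, the higher of the two numbers measured so far and so the weaker inhibition. Compound 2 `COC(=O)c1ccc(CN(CCCc2c(N)nc(N)nc2O)c2cc(F)c([N+](=O)[O-])cc2[N+](=O)[O-])cc1` gives 3900 nM. Compound 3 `Nc1nc(N)c(CCCN(Cc2ccc(NC(CCC(=O)O)C(=O)O)cc2)c2cc(F)ccc2[N+](=O)[O-])c(O)n1` departs from compound 1 at a single place: hydrogen in place of nitro on an aromatic carbon. This is hydrogen in place of nitro on an aromatic carbon, ortho to a fluoro group and meta to a nitro group.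

Among the compounds with values here, only one measured step is available, an 11-fold lower number from compound 1 to compound 2 (1.05 log units; beyond the scatter). It is large, but it is methoxycarbonyl in place of (1,3-dicarboxypropyl)amino, elsewhere in the molecule, and both nitro groups stay untouched. That step shows how far numbers can move in this small set, yet it says nothing direct about losing a nitro group. Within the data shown here, no measured pair tests this change. A modest step in this assay is therefore expected, perhaps none beyond the scatter, leaning towards a higher number as a judgement only. The expected change is a 1.4-fold higher number from compound 1 to compound 3 (0.13 log units; within the scatter). Compound 3 is estimated at 60000 nM, with an expected range from 20000 nM to 200000 nM.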

Compound 3, half-maximal inhibitory concentration: > 100000 nM
Compound 3: no number, only a limit; the forecaster's own chance of this, stated with the estimate: 30%; at least 1.6-fold (0.22 log units) between middle value and limit.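

In this assay, the step from hydrogen in place of nitro gives an at least 2.2-fold higher number from compound 1 to compound 3 (0.35 log units; beyond the scatter). Going by these compounds alone, this is the first measured change that touches either nitro group, and it shows that losing the nitro group at this position, on the aromatic carbon ortho to a fluoro group and meta to a nitro group, moves the read-out towards weaker inhibition, beyond the scatter. Compound 3 gives > 100000 nM, which is a limit of the assay and not a number, so only the direction and a minimum size of the step can be read, and how much further it extends remains unknown: the limit of > 100000 nM in this assay, at which 1 of the 3 values shown sits.

The compounds shown do not tell whether the nitro group is specifically needed on this aromatic carbon, or whether an amine or a nitrile there would give a number close to that of compound 1. From the compounds shown here alone, it also remains open whether the same change on compound 2, which carries methoxycarbonyl in place of the (1,3-dicarboxypropyl)amino group, would move the number in the same direction and by a similar amount.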